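The compounds below may be only part of what the source reports. "The series", "measured", "known", "first", "only" and "open" are said of these compounds alone.

Measured compounds:
Compound 1 `COc1ccccc1/C=C/C(=O)OC/C=C/c1cc(OC)c(OC)cc1OC`: 50%
Compound 2 `COc1cc(OC)c(OC)cc1/C=C/COC(=O)/C=C/c1c(OC)ccc(OC)c1OC`: 50%
Compound 3 `COc1cc(OC)c(OC)cc1/C=C/COC(=O)/C=C/c1ccc(F)cc1`: 0%

In a functional assay on the whole organism (strain Kunming) with Mus musculus as the target, with a stated time of 0.5 h, at a dose of 300 mg/kg by the intraperitoneal route (on this read-out lower numbers stand for a stronger effect and higher numbers for a weaker effect at the one dose given), compound 3 gives the lowest of the three numbers, meaning the strongest effect at the one dose. Among the compounds with values here, compound 1 and compound 2 both give numbers far higher; the one measured step reads a number 50 percentage points lower from compound 1 to compound 3 (beyond the scatter), and compound 2 stands as high as compound 1.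

Compound 4 `COc1cc(OC)c(OC)cc1/C=C/COC(=O)/C=C/c1ccc(Cl)cc1` is still to be measured. It differs from compound 3 as chloro in place of fluoro on an aromatic carbon

Within the data shown here, the only measured step, a number 50 percentage points lower from compound 1 to compound 3 (beyond the scatter), exchanged the whole aryl substituent, not one halogen for another, so no measured step bears directly on the fluoro-to-chloro exchange. A halogen exchange of this kind gives no footing for a large step in either direction; the expectation is a step within the scatter, a number 10 percentage points higher from compound 3 to compound 4 (within the scatter), with the number for compound 4 estimated near that of compound 3. Compound 4 is therefore expected to give about 10%, ranging from 0% to 40% in this assay.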

Compound 4, a percentage reported as activity, at one dose (the size of the read-out at that dose, not a potency): 25%
Beside the measured number, compound 4's estimate is 15 percentage points below it; measured number inside the range.
By their numbers in this assay, from the lowest: compound 3; then compound 4; then compounds 1 and 2 (each within the scatter of the next).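

In this assay the identity of the halogen on this aromatic carbon matters: chloro in place of fluoro gives a number 25 percentage points higher from compound 3 to compound 4 (beyond the scatter) and so a single-atom exchange moves the read-out beyond the scatter, with the stronger effect staying with fluoro. The 4-chlorophenyl group still improves on the 2-methoxyphenyl group, giving a number 25 percentage points lower from compound 1 to compound 4 (beyond the scatter) so that both halogen compounds stand lower than compound 1, though the chloro compound keeps only part of the step seen with fluoro (a number 50 percentage points lower from compound 1 to compound 3 (beyond the scatter)). No measurement on hand accounts for the difference between the two halogens.

From the compounds shown here alone, two halogens do not make a trend, so it remains open whether bromo, methyl or trifluoromethyl at this carbon would read closer to fluoro or to chloro. Also open, going by these compounds, is how an amine or a carboxylic acid at this carbon would read, and whether the order of compound 3 and compound 4 holds at other doses.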